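Shortening the Amide Side Chain in a Cytotoxic Series

The source may report more compounds than this note shows. Statements on the series, on what has been measured and on what is new or still open speak of the compounds shown alone.

Measured compounds in a functional assay on HeLa cells (Homo sapiens) for cytotoxicity, read by resazurin assay, with a stated time of 72 h; a higher number here means a weaker inhibitor, a lower number a stronger inhibitor:
Compound 1 `CCSC(=S)SCC(=O)c1ccc(C(=O)N[C@@H](C)c2ccccc2)s1` gives 15800 nM.
Compound 2 `CCSC(=S)SCC(=O)c1ccc(C(=O)NCCOc2ccccc2)cc1` gives 18200 nM.

Compound 2 has the higher of the two numbers, yet its distance to compound 1 lies within the usual scatter, so the two cannot be told apart. Compound 3 `CCSC(=S)SCC(=O)c1ccc(C(=O)NCc2ccccc2)cc1` differs from compound 2 in one place: phenyl in place of phenoxymethyl on a saturated chain carbon bound to an amide-type nitrogen. Going by the values given here, no measured pair shows this change, so nothing directly tells its size. Because compound 2 gives 18200 nM and compound 1 gives 15800 nM, compound 3 is expected to stay in the same range, and the step of a 1.1-fold lower number from compound 2 to compound 3 (0.03 log units; within the scatter) is expected to be none beyond the scatter. Compound 3 is estimated at 17000 nM, in the range 8000 nM to 36000 nM.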

Compound 3, half-maximal inhibitory concentration: 23900 nM
The estimate for compound 3 lay 1.4-fold (0.15 log units) below the measured number; the measured number falls inside the stated range.
By their numbers in this assay, from the lowest: compounds 1, 2 and 3 (each within the scatter of the next).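

In this assay, phenyl in place of phenoxymethyl on a saturated chain carbon bound to an amide-type nitrogen gives a 1.3-fold higher number from compound 2 to compound 3 (0.12 log units; within the scatter). Going by these compounds alone, this is the first direct reading of this change, and it shows that 2-phenoxyethyl and benzyl cannot be told apart at this position. No measurement shown here bears on this result. As far as these compounds go, whether an amine, a carboxylic acid or a longer chain at this position would give a step beyond the scatter remains open.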